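Notes on a triazole series: compound 1 to compound 4

The compounds below may be only part of what the source reports. "The series", "measured", "known", "first", "only" and "open" are said of these compounds alone.

Measured so far in a functional assay on SW-620 cells (Homo sapiens) for antiproliferative activity, read by MTT assay, with a stated time of 72 h; a lower number here means a stronger inhibitor, a higher number a weaker inhibitor:
compound 1, `O=C1O[C@H]([C@@H](O)Cn2cc(-c3cc(F)cc(F)c3)nn2)C(OCc2ccccc2)=C1OCc1ccccc1`: > 100000 nM
compound 2, `O=C1O/C(=C\Cn2cc(-c3cccc(O)c3)nn2)C(OCc2ccccc2)=C1OCc1ccccc1`: 69800 nM
compound 3, `O=C1O/C(=C\Cn2cc(-c3cc(C(F)(F)F)cc(C(F)(F)F)c3)nn2)C(OCc2ccccc2)=C1OCc1ccccc1`: > 100000 nM.

For compound 1 this assay reports only a limit, > 100000 nM, and not a number. Compound 3 likewise sits at a limit, > 100000 nM. Among the compounds with values here, compound 2 is the one member of the set with a numerical value, 69800 nM. In short, (the limit of > 100000 nM in this assay, at which 2 of the 3 values shown sit). Within the data shown here, compound 1 therefore stands at the weak end of what is known, with no measured number of its own, and no step between two measured compounds that differ in one place is available to calibrate how a single change moves this assay.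

Compound 4, `O=C1O[C@H]([C@@H](O)Cn2ccnn2)C(OCc2ccccc2)=C1OCc1ccccc1`, is not yet measured. It differs from compound 1 in one place: hydrogen in place of 3,5-difluorophenyl on an aromatic carbon. The shared core of compound 1 is otherwise unchanged. No size can be read from the measured compounds for this kind of change, and the starting point is itself a limit. The step expected here, a step that the limit leaves unreadable from compound 1 to compound 4, is none beyond the scatter; compound 4 is expected to remain at the limit of this assay. Compound 4 is estimated at 150000 nM, with a range from 50000 nM to 500000 nM, most likely reported as a limit rather than a number.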

Compound 4, half-maximal inhibitory concentration: > 100000 nM
Compound 4: no number, only a limit; the forecaster's own chance of this, stated with the estimate: 80%; the middle value is on the limit's open side.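

In this assay compound 4 gives > 100000 nM, a limit and not a number. Compound 1 also has only a limit, and no step can be read between compound 1 and compound 4. The compounds shown leave open whether hydrogen in place of 3,5-difluorophenyl changes activity at all, with most values resting on one figure: the limit of > 100000 nM in this assay, at which 3 of the 4 values shown sit.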